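A few compounds are considered here, and "the series" means these few. Any claim that something is new, unique, unknown or untested is made for them only; others in the source may bear on it.

Measured so far in an assay on isolated protein for binding affinity to Equilibrative nucleoside transporter 1 (Homo sapiens); a higher number here means a weaker inhibitor, a lower number a stronger inhibitor:
- compound 1, `O=[N+]([O-])c1cccc2c1CCN(c1ncnc3c1nc1n3[C@@H]3O[C@H](CO1)[C@@H](O)[C@H]3O)C2`: 7410000 nM
- compound 2, `CCCCCNc1ncnc2c1ncn2[C@@H]1O[C@H](CO)[C@@H](O)[C@H]1O`: 13500 nM
- compound 3, `OC[C@H]1O[C@@H](n2cnc3c(OCc4ccccc4)ncnc32)[C@H](O)[C@@H]1O`: 2090 nM

Compound 3 gives the lowest number of the three; its gap to compound 2 and its far larger gap to compound 1 both lie beyond the scatter. Compound 4, `OC[C@H]1O[C@@H](n2cnc3c(SCC4CCCCC4)ncnc32)[C@H](O)[C@@H]1O`, differs from compound 3 in one place: (cyclohexylmethyl)sulfanyl in place of benzyloxy on an aromatic carbon. Among the measured compounds shown here, the single measured step, a 6.5-fold lower number from compound 2 to compound 3 (0.81 log units; beyond the scatter), changes a different group and says nothing about exchanging oxygen for sulfur or an aromatic ring for a saturated one, so no measured step bears directly on this change. With nothing in the data pointing either way, the number for compound 4 is expected to stay close to that of compound 3, estimated at 900 nM with a range of 150 nM to 5000 nM, a step of a 2.3-fold lower number from compound 3 to compound 4 (0.37 log units; beyond the scatter).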

Compound 4, half-maximal inhibitory concentration: 1550 nM
Compound 4: the middle estimate sits 1.7-fold (0.24 log units) below what was measured; the measured number falls inside the stated range.
By their numbers in this assay, from the lowest: compounds 4 and 3 (each within the scatter of the next); then compound 2; then compound 1.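

In this assay, exchanging benzyloxy for (cyclohexylmethyl)sulfanyl on this aromatic carbon gives a 1.3-fold lower number from compound 3 to compound 4 (0.13 log units; within the scatter), so replacing the aromatic ring with a saturated one and oxygen with sulfur together produces no readable change. Replacing pentylamino with the same group gives an 8.7-fold lower number from compound 2 to compound 4 (0.94 log units; beyond the scatter), a gap beyond the scatter. No evidence here explains these results. From the compounds shown here alone, the ring and the linking atom changed together, so their separate contributions remain open: benzylsulfanyl or cyclohexylmethoxy at this carbon would separate them.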